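The source may hold more compounds than are shown below. What is called first, only, known or untested is meant among the compounds shown, and "the series" means these compounds.

Compound 1 `Cc1c(C)c2c(c(C)c1O)CCC(C)(C(=O)N1CCN(c3ccc(Cl)cc3)CC1)O2` and compound 2 `COc1ccc(N2CCN(C(=O)C3(C)CCc4c(C)c(O)c(C)c(C)c4O3)CC2)cc1` share one core and differ by methoxy in place of chloro on an aromatic carbon. In a functional assay (brain) for inhibition, with Rattus norvegicus as the target (on this read-out higher numbers stand for weaker inhibition and lower numbers for stronger inhibition), compound 1 gives 800 nM, and compound 2 gives 700 nM; the change brings a 1.1-fold lower number from compound 1 to compound 2 (0.06 log units; within the scatter). Compound 3 `Cc1c(C)c2c(c(C)c1O)CCC(C)(CN1CCN(c3ccc(Cl)cc3)CC1)O2` carries the chloro-bearing ring on a second core; how that core differs from the core of compound 1 is not broken down here. In this assay compound 3 gives 900 nM. Compound 4 `COc1ccc(N2CCN(CC3(C)CCc4c(C)c(O)c(C)c(C)c4O3)CC2)cc1`, not yet measured, differs from compound 3 by methoxy in place of chloro on an aromatic carbon, the same change as that seen between compound 1 and compound 2. The expected step is a 1.1-fold lower number from compound 3 to compound 4 (0.05 log units; within the scatter), which rests on the observation that a 1.1-fold lower number from compound 1 to compound 2 (0.06 log units; within the scatter) stayed within the scatter. Compound 4 is accordingly estimated at 800 nM in this assay, most likely between 400 nM and 1600 nM.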

Compound 4, half-maximal inhibitory concentration: 200 nM
Beside the measured number, compound 4's estimate is 4.0-fold (0.60 log units) above it, outside the stated range (below it).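

In this assay, methoxy in place of chloro brings a 4.5-fold lower number from compound 3 to compound 4 (0.65 log units; beyond the scatter), so the change did not carry over unaltered from one core to the other: the same change on two cores in this assay, a 1.1-fold lower number (0.06 log units; within the scatter) from compound 1 to compound 2 and a 4.5-fold lower number (0.65 log units; beyond the scatter) from compound 3 to compound 4, 3.9-fold (0.60 log units) apart, beyond the scatter of two such steps

In these two pairs, then, the size of the step goes with the core, and a step read on one core was a poor guide to the other. They do not show what in the cores causes this, and two pairs give no general rule for the series.

The compounds shown leave open whether other groups on that aromatic carbon, such as fluoro, methyl or a dimethylamino group, would also give steps that differ between the two cores.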